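The source may report more compounds than this note shows. Statements on the series, on what has been measured and on what is new or still open speak of the compounds shown alone.

Measured compounds in a functional assay on KYSE-450 cells (Homo sapiens) for inhibition, read by CCK-8 assay, with a stated time of 48 h; a higher number here means a weaker inhibitor, a lower number a stronger inhibitor:

- compound 1, `COc1ccc(CN(C(=O)CSC(=S)N2CCN(C(=O)OC(C)(C)C)CC2)c2ccc(Cl)cc2)cc1`; in this assay compound 1 gives > 20000 nM, a limit of the assay, not a number
- compound 2, `COc1ccc(CN(C(=O)CSC(=S)N2CCN(C(=O)OC(C)(C)C)CC2)c2ccc(Br)cc2)cc1`; in this assay compound 2 gives > 20000 nM, likewise a limit
- compound 3, `COc1cc(N(Cc2ccc(Cl)cc2)C(=O)CSC(=S)N2CCN(C(=O)OC(C)(C)C)CC2)cc(OC)c1OC`; in this assay compound 3 gives 11900 nM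

Compound 1 and compound 2 differ in one place only, (bromo in place of chloro on an aromatic carbon). The step that the two limits leave unreadable from compound 1 to compound 2 cannot be sized, because the limit of > 20000 nM in this assay, at which 2 of the 3 values shown sit, covers both ends of it. Compound 3 carries a different core; how the core of compound 3 differs from the core of compound 1 is not broken down here. Among the measured compounds shown here, of the three values, only that of compound 3 is a number.

Compound 4, `COc1cc(N(Cc2ccc(Br)cc2)C(=O)CSC(=S)N2CCN(C(=O)OC(C)(C)C)CC2)cc(OC)c1OC`, is not yet measured. For the measured compounds named here, it differs from compound 3 by bromo in place of chloro on an aromatic carbon, which is the same change as the one from compound 1 to compound 2, at a place described in the same words. Going by the values given here, since the measured instance of this change is unreadable, the expectation for compound 4 rests on the single number for compound 3 and on the change being a one-atom halogen swap. The step of a 1.0-fold higher number from compound 3 to compound 4 (0.00 log units; within the scatter) is therefore expected to be small, within the usual scatter. Compound 4 is estimated at 12000 nM in this assay, with a range from 6000 nM to 24000 nM. A limit rather than a number for compound 4 is a real possibility given where compound 3 already sits.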

Compound 4, half-maximal inhibitory concentration: 10700 nM
Compound 4: middle estimate off by 1.1-fold (0.05 log units), on the high side; the measured number falls inside the stated range.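

In this assay, bromo in place of chloro on the core of compound 3, read as 4-chlorobenzyl to 4-bromobenzyl, gives a 1.1-fold lower number from compound 3 to compound 4 (0.05 log units; within the scatter), so on this core the two halogens cannot be told apart. The same change on the core of compound 1 gives no second reading, because compound 1 and compound 2 both give limits of the assay rather than numbers: the limit of > 20000 nM in this assay, at which 2 of the 4 values shown sit. The swap is therefore readable on one core only, so these data show no change in this assay on the core of compound 3 but do not show that the change carries over from one core to another, and a single step within the scatter sets no rule for the series.

The compounds shown hold only chloro and bromo at this place, para to a large group, which leaves open what an amine or a carboxylic acid there would give on either core. Also open, as far as these compounds go, is whether the tert-butyl carbamate shared by all four compounds matters to the reading in this assay, for instance whether a free amine in its place would turn the core of compound 1 into one on which the halogen swap can be sized.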